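Swapping a Furan for a Methylpyridine on the Sulfonyl Sulfur

A few compounds are considered here, and "the series" means these few. Any claim that something is new, unique, unknown or untested is made for them only; others in the source may bear on it.

Compound 2 `CNCc1cn(S(=O)(=O)c2ccoc2)c(-c2cccnc2F)c1F` and compound 1 `CNCc1cn(S(=O)(=O)c2ccco2)c(-c2cccnc2F)c1F` share one core and differ only in the ring carried on the sulfonyl sulfur. In a physicochemical assay for lipophilicity, read by HPLC, at pH 7.4 (on this read-out higher numbers stand for higher lipophilicity and lower numbers for lower lipophilicity), compound 2 gives 0.45, and compound 1 gives 0.2; these two numbers lie within the usual scatter of each other, so neither can be set apart from the other. Within the data shown here, the single measured step, a number 0.25 log units higher from compound 1 to compound 2 (within the scatter), moves one furan ring for another and does not reach beyond the scatter. Compound 3 `CNCc1cn(S(=O)(=O)c2cnccc2C)c(-c2cccnc2F)c1F` is not yet measured and differs from compound 2 as follows: 4-methylpyridin-3-yl in place of furan-3-yl on a sulfonyl sulfur. Among the measured compounds shown here, no measured step covers this change, so the only guide is that the earlier exchange of the ring on this sulfur did not move the value beyond the scatter. A step no larger than the scatter is therefore expected, a number 0.05 log units higher from compound 2 to compound 3 (within the scatter). Compound 3 is estimated at 0.5, with a range from 0 to 1.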

Compound 3, distribution coefficient: 0.43
Beside the measured number, compound 3's estimate is 0.07 log units above it; the range from low to high includes it.
By their numbers in this assay, from the lowest: compounds 1, 3 and 2 (each within the scatter of the next).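

On the sulfonyl sulfur, the exchange now goes beyond one furan for another: a six-membered aromatic ring, 4-methylpyridin-3-yl, with more heavy atoms, enters in place of the five-membered furan-3-yl, and this assay shows a number 0.02 log units lower from compound 2 to compound 3 (within the scatter). Set against the other furan, furan-2-yl, the same ring gives a number 0.23 log units higher from compound 1 to compound 3 (within the scatter), so this read-out cannot tell the three rings apart, even across a change of ring size and hetero atom. Nothing available explains why these numbers stay so close.

All three groups on this sulfur are aromatic rings with one hetero atom, so the compounds shown cannot say how far this holds for other kinds of group. As far as these compounds go, a ring bearing an amine or a carboxylic acid, or a longer chain on the sulfur, might give a step beyond the scatter in this assay, and that remains open.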